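Replacing methoxy with ethoxycarbonyl in compound 2

The compounds below may be only part of what the source reports. "The series", "measured", "known", "first", "only" and "open" are said of these compounds alone.

Compound 1 `COc1cc(Nc2nc(Nc3ccc(Cl)cc3)nnc2Cl)cc(OC)c1OC`: 32600 nM
Compound 2 `COc1ccc(Nc2nnc(Cl)c(Nc3cc(OC)c(OC)c(OC)c3)n2)cc1`: 22300 nM
Compound 3 `COc1cc(Nc2nnc(Cl)c(Nc3cc(OC)c(OC)c(OC)c3)n2)cc(OC)c1OC`: > 50000 nM (a limit)

In a functional assay on ECa-109 cells for inhibition, with ECa-109 cell line (Homo sapiens) as the target, read by MTT assay, with a stated time of 48 h (a lower number here means a stronger inhibitor, a higher number a weaker inhibitor), compound 2 and compound 1 lie within the scatter of each other. Compound 3 gives only a limit, > 50000 nM.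

Compound 4 `CCOC(=O)c1ccc(Nc2nnc(Cl)c(Nc3cc(OC)c(OC)c(OC)c3)n2)cc1` carries ethoxycarbonyl in place of the methoxy of compound 2, on an aromatic carbon, para to a large group: ethoxycarbonyl in place of methoxy on an aromatic carbon. For the measured compounds named here, the only measured step at this carbon is methoxy in place of chloro, a 1.5-fold lower number from compound 1 to compound 2 (0.16 log units; within the scatter). On that evidence, no step beyond the scatter is expected in this assay. The expected change is a 1.1-fold higher number from compound 2 to compound 4 (0.05 log units; within the scatter). Compound 4 is estimated at 25000 nM, with an expected range of 10000 nM to 50000 nM.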

Compound 4, half-maximal inhibitory concentration: 46600 nM
Estimate against measurement, compound 4: 1.9-fold (0.27 log units) below; the range from low to high includes it.
By their numbers in this assay, from the lowest: compounds 2, 1 and 4 (each within the scatter of the next, the first and the last beyond it). At a limit, above all of these: compound 3.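

In this assay, for the compounds shown here, ethoxycarbonyl on this aromatic carbon, para to a large group, gives the first step at this position beyond the scatter, though a modest one (a 2.1-fold higher number from compound 2 to compound 4 (0.32 log units; beyond the scatter)). Against chloro on the same carbon it stays within the scatter (a 1.4-fold higher number from compound 1 to compound 4 (0.16 log units; within the scatter)), so the change is small and depends on the group it replaces. Compound 3 remains at a limit: the limit of > 50000 nM in this assay, at which 1 of the 4 values shown sits.

Going by these compounds, what an amine or a carboxylic acid on this carbon would give stays open. So does the effect of a longer chain on the ester.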